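Methoxyphenyl change on the amine nitrogen: working notes

This account rests on a few compounds, and the source may have more. Where it says the series, first, only, none or still open, it means among the compounds named here.

Compound 1 `C=C1[C@@H](OC(C)=O)C[C@@H]2[C@](C)(CO[Si](C)(C)C(C)(C)C)[C@H](OC(C)=O)CC[C@@]2(C)[C@@H]1C[C@@H](Nc1ccccc1F)C1=CCOC1=O`: 2930 nM
Compound 2 `C=C1[C@@H](OC(C)=O)C[C@@H]2[C@](C)(CO[Si](C)(C)C(C)(C)C)[C@H](OC(C)=O)CC[C@@]2(C)[C@@H]1C[C@@H](Nc1ccc(OC)cc1)C1=CCOC1=O`: 4280 nM
Compound 3 `C=C1[C@@H](OC(C)=O)C[C@@H]2[C@](C)(CO[Si](C)(C)C(C)(C)C)[C@H](OC(C)=O)CC[C@@]2(C)[C@@H]1C[C@@H](Nc1cccc(OC)c1)C1=CCOC1=O`: not yet measured

In a functional assay on MCF7 cells (Homo sapiens) for cytotoxicity, read by sulforhodamine B assay (on this read-out lower numbers stand for stronger inhibition and higher numbers for weaker inhibition), compound 2 gives 4280 nM. Going by the values given here, this lies within the scatter of compound 1, the only other measured compound, so no order can be read between the two.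

The next step goes from compound 2 to compound 3, with 3-methoxyphenyl in place of 4-methoxyphenyl on an amine nitrogen. The shared core stays untouched.

Among the compounds with values here, one measured step bears on this change: a 1.5-fold higher number from compound 1 to compound 2 (0.16 log units; within the scatter). It also exchanges the aryl group on that nitrogen, and it stays inside the scatter. Within the data shown here, it is the only evidence available, and it does not test the methoxy shift on its own. Two compounds establish no trend, so no step beyond the scatter is expected in this assay, and neither direction is favoured.

The estimated change is a 1.1-fold lower number from compound 2 to compound 3 (0.05 log units; within the scatter).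

Compound 3 is expected at 3800 nM, within an estimated range of 2000 nM to 7000 nM.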

Compound 3, half-maximal inhibitory concentration: 28100 nM
Estimate against measurement, compound 3: 7.4-fold (0.87 log units) below; measured number above the stated range.
By their numbers in this assay, from the lowest: compounds 1 and 2 (each within the scatter of the next); then compound 3.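

In this assay the aryl group on the amine nitrogen is not indifferent to where its methoxy group sits: 3-methoxyphenyl in place of 4-methoxyphenyl gives a 6.6-fold higher number from compound 2 to compound 3 (0.82 log units; beyond the scatter) even though the two groups hold the same atoms, joined differently. The exchange of 2-fluorophenyl for 3-methoxyphenyl gives a 9.6-fold higher number from compound 1 to compound 3 (0.98 log units; beyond the scatter) and so compound 3 is the weakest of the three, while compound 1 and compound 2 remain within the scatter of each other, which shows that aryl changes at this nitrogen can move the number well beyond what the first step suggested. Nothing measured here accounts for the size of the methoxy shift, and the reason for it remains unknown.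

Going by these compounds, what stays open is whether the 3-methoxyphenyl result reflects the methoxy group itself or any group at that place on the ring, a question that a 3-hydroxyphenyl or 3-fluorophenyl analogue would address. Also open is how plain phenyl or a benzyl group on the same nitrogen would compare, as all three compounds shown carry a substituted phenyl there on an otherwise unchanged shared core.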